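This account rests on a few compounds, and the source may have more. Where it says the series, first, only, none or still open, it means among the compounds named here.

Working notes on the series. The shared core of compound 1 `C[C@H](c1ccc(C(=O)NCCC(=O)O)cc1)N1C(=O)C(c2cccc(C3CC3)c2)=N[C@]12CC[C@@H](C(C)(C)C)CC2` carries a 3-cyclopropylphenyl group on the carbon with a double bond to nitrogen; in a functional assay on CHO cells for antagonist activity at Glucagon receptor (Homo sapiens), read by cAMP accumulation, with stated times of 30 min and 45 min (a higher number here means a weaker inhibitor, a lower number a stronger inhibitor), compound 1 gives 340 nM, the highest of the three numbers in hand. Compound 2 `CC(C)(C)CC[C@H](c1ccc(C(=O)NCc2nn[nH]n2)cc1)N1C(=O)C(c2cccc(C(F)(F)F)c2)=N[C@]12CC[C@@H](C(C)(C)C)CC2` gives 180 nM in this assay, and its number and that of compound 1 lie within the scatter of each other. Compound 3 `CC(C)CC[C@H](c1ccc(C(=O)NCc2nn[nH]n2)cc1)N1C(=O)C(c2cc(Cl)cc(Cl)c2)=N[C@]12CC[C@@H](C(C)(C)C)CC2` gives 150 nM in this assay, a lower number than compound 1 and a gap beyond the scatter. Compounds 2 and 3 differ from compound 1 in more than one place, so none of these pairs isolates a single change.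

Compound 4 `C[C@H](c1ccc(C(=O)NCCC(=O)O)cc1)N1C(=O)C(c2ccccc2F)=N[C@]12CC[C@@H](C(C)(C)C)CC2` differs from compound 1 in one place: 2-fluorophenyl in place of 3-cyclopropylphenyl on a carbon with a double bond to nitrogen. Going by the values given here, no measured pair in this set shows what this exchange does on its own, so the direction can only be guessed from the standing of compound 1. For compound 4 a step from compound 1 is expected that is modest, toward a higher number, possibly beyond the scatter, as a 2.1-fold higher number from compound 1 to compound 4 (0.31 log units; beyond the scatter). Compound 4 is therefore estimated at 700 nM in this assay, with a range from 200 nM to 2500 nM.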

Compound 4, half-maximal inhibitory concentration: 350 nM
The estimate for compound 4 lay 2.0-fold (0.30 log units) above the measured number; the measured number falls inside the stated range.
By their numbers in this assay, from the lowest: compounds 3, 2, 1 and 4 (each within the scatter of the next, the first and the last beyond it).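

In this assay, going by these compounds alone, 2-fluorophenyl in place of 3-cyclopropylphenyl on a carbon with a double bond to nitrogen gives a 1.0-fold higher number from compound 1 to compound 4 (0.01 log units; within the scatter), the first step that isolates a single change. At this position, with the rest of the compound 1 structure held fixed, the two groups cannot be told apart in this assay, although the entering group lacks the three-membered ring, has fewer heavy atoms and carries a fluorine. So the substituent on this phenyl ring can differ in identity, size and printed place without a step beyond the scatter for this one pair, and nothing measured here bears on why the two compounds read alike.

One pair leaves open whether the same exchange would read alike with the longer chains of compounds 2 and 3 or with the other acidic side chain they carry. It also leaves open what an unsubstituted phenyl, a 3-methoxyphenyl or a 3-aminophenyl group would give on this carbon, and so whether any group here moves the number beyond the scatter.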